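A few compounds are considered here, and "the series" means these few. Any claim that something is new, unique, unknown or untested is made for them only; others in the source may bear on it.

Measured compounds in a functional assay on NCI-H460 cells (Homo sapiens); a lower number here means a stronger inhibitor of growth, a higher number a weaker inhibitor of growth:
compound 1, `COc1cc(CSc2cc(Cl)c(-c3nnc(-c4ccc(Cl)cc4)s3)cc2S(=O)(=O)NC(=N)NO)cc(OC)c1OC`: 34700 nM
compound 2, `N=C(NO)NS(=O)(=O)c1cc(-c2nnc(-c3ccc(Cl)cc3)s2)c(Cl)cc1SCc1ccccc1`: 1730 nM

Compound 1 holds the highest number of the two; compound 2 stands nearest. Among the compounds with values here, the only measured step, a 20-fold lower number from compound 1 to compound 2 (1.30 log units; beyond the scatter), is phenyl in place of 3,4,5-trimethoxyphenyl on a saturated chain carbon bound to a sulfur. Compound 3, `COc1cc(CSc2cc(Cl)c(-c3nc(-c4ccccc4)no3)cc2S(=O)(=O)NC(=N)NO)cc(OC)c1OC`, is not yet measured. It differs from compound 1 at another place: 3-phenyl-1,2,4-oxadiazol-5-yl in place of 5-(4-chlorophenyl)-1,3,4-thiadiazol-2-yl on an aromatic carbon. Within the data shown here, the change in compound 3 keeps the 3,4,5-trimethoxyphenyl of compound 1 untouched, so the measured step does not bear on it directly; it only shows that this assay moves a great deal when the chain side of the shared core is altered, while no measured step tests an exchange of the ring bound to the aromatic carbon. No direction can be read from the two numbers at hand. Compound 3 is therefore expected to stay close to compound 1, with a wide range, at an estimated 30000 nM, between 6000 nM and 100000 nM, which means an expected step of a 1.2-fold lower number from compound 1 to compound 3 (0.06 log units; within the scatter).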

Compound 3, concentration for 50% growth inhibition: 4370 nM
Beside the measured number, compound 3's estimate is 6.9-fold (0.84 log units) above it; measured number below the stated range.
By their numbers in this assay, from the lowest: compound 2; then compound 3; then compound 1.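

In this assay, the group on the aromatic carbon para to a large group also carries weight: 3-phenyl-1,2,4-oxadiazol-5-yl in place of 5-(4-chlorophenyl)-1,3,4-thiadiazol-2-yl gives a 7.9-fold lower number from compound 1 to compound 3 (0.90 log units; beyond the scatter), with the 3,4,5-trimethoxyphenyl left in place. The number therefore responds at a second place on the shared core, not only at the group on the saturated chain carbon bound to a sulfur. The exchange alters two things at once, since the five-membered aromatic ring swaps sulfur for oxygen and its hetero atoms are rearranged, while the chlorine leaves the six-membered aromatic ring, and no evidence on hand explains the step or divides it between these parts.

Open, as far as these compounds go, is whether phenyl on the chain carbon and 3-phenyl-1,2,4-oxadiazol-5-yl on the aromatic carbon would add up when combined on one core, as the two changes are seen here only separately, each starting from the 3,4,5-trimethoxyphenyl compound. Also open, from the compounds shown here alone, is whether the six-membered ring on the five-membered ring is needed at all, which a carboxylic acid or a plain amide on the same aromatic carbon would test, and whether a 4-chlorophenyl on the oxadiazole would separate the chlorine from the ring exchange.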